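Swapping methoxycarbonyl for tert-butyl on an aromatic carbon

The source may report more compounds than this note shows. Statements on the series, on what has been measured and on what is new or still open speak of the compounds shown alone.

- Compound 1 `O=C(C[C@H]1CC(=O)c2c(F)cc(F)cc21)N[C@@H]1O[C@H](CO)[C@@H](O)[C@H](O)[C@H]1O` gives 31.7 nm/s as its value
- Compound 2 `COc1cc(/C=C/C(=O)N[C@@H]2O[C@H](CO)[C@@H](O)[C@H](O)[C@H]2O)cc(OC)c1` gives 80 nm/s as its value
- Compound 3 `COC(=O)c1ccc(/C=C/C(=O)N[C@@H]2O[C@H](CO)[C@@H](O)[C@H](O)[C@H]2O)cc1` gives 26.3 nm/s as its value

All three values come from an ADME assay on Caco-2 cells (Homo sapiens) for permeability (a higher number here means that the compound crosses the layer faster, a lower number that the compound crosses the layer more slowly), and they give a small picture. Compound 3 at 26.3 nm/s and compound 1 at 31.7 nm/s lie within the usual scatter of each other. Compound 2 at 80 nm/s stands higher than compound 3, and that gap goes beyond the scatter.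

The next compound to be measured is compound 4 `CC(C)(C)c1ccc(/C=C/C(=O)N[C@@H]2O[C@H](CO)[C@@H](O)[C@H](O)[C@H]2O)cc1`, which has tert-butyl in place of methoxycarbonyl on an aromatic carbon. Within the data shown here, no two measured compounds differ in only one place, so no measured step can guide this swap. Among the measured compounds shown here, the only hint is that compound 2 at 80 nm/s shows numbers clear of compound 3 do occur in this small set. A modest upward move in this assay is therefore expected, an estimated 2.3-fold higher number from compound 3 to compound 4 (0.36 log units; beyond the scatter) that remains uncertain. For compound 4 the estimate is 60 nm/s with an expected range from 25 nm/s to 150 nm/s as the likely span.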

Compound 4, apparent permeability: 87.7 nm/s
The estimate for compound 4 lay 1.5-fold (0.16 log units) below the measured number; the range from low to high includes it.
By their numbers in this assay, from the lowest: compounds 3 and 1 (each within the scatter of the next); then compounds 2 and 4 (each within the scatter of the next).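

Among these compounds, on this aromatic carbon, para to a large group, compounds 3 and 4 give the first comparison that differs in only one place: in this assay the swap from methoxycarbonyl to tert-butyl gives a 3.3-fold higher number from compound 3 to compound 4 (0.52 log units; beyond the scatter) in this single pair. Both groups have 4 heavy atoms, yet tert-butyl has no oxygen and 0 hydrogen-bond acceptors, so a swap that leaves the heavy-atom count unchanged can still move the number beyond the scatter. Nothing measured here explains the rise.

This one step changes the oxygens, the acceptors and the double bond together, so it cannot show which of them matters. Also open, from the compounds shown here alone, is where an amine, a carboxylic acid or a methyl group at this place would fall relative to methoxycarbonyl and tert-butyl.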